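Amine Methylation in a Dimethoxyphenyl Uracil GnRH Series

The source may hold more compounds than are shown below. What is called first, only, known or untested is meant among the compounds shown, and "the series" means these compounds.

Measured so far:
Compound 1 `COc1cccc(-c2c(C)n(Cc3c(F)cccc3F)c(=O)n(C[C@@H](N)CCc3ccccc3)c2=O)c1F` gives 965 nM in an assay on HEK293 cells for binding affinity to Gonadotropin-releasing hormone receptor (Homo sapiens), read by radioligand binding; on this read-out lower numbers stand for stronger inhibition and higher numbers for weaker inhibition.
Compound 2 `COc1cccc(-c2c(C)n(Cc3c(F)cccc3F)c(=O)n(C[C@H](N)CC(C)C)c2=O)c1F` gives 6.4 nM in this assay.

Among the compounds with values here, compound 2 holds the lowest number of the two measured compounds, its only neighbour being compound 1, with the step of a 150-fold lower number from compound 1 to compound 2 (2.18 log units; beyond the scatter) coming from the exchange of 1-amino-3-methylbutyl for 1-amino-3-phenylpropyl on the chain carbon bound to the aromatic nitrogen.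

Compound 3 `CN[C@H](CC(C)C)Cn1c(=O)c(-c2cccc(OC)c2F)c(C)n(Cc2c(F)cccc2F)c1=O` differs from compound 2 only in methyl in place of hydrogen on an amine nitrogen. Within the data shown here, no measured step touches the amine nitrogen itself; the single step on record, from compound 1 to compound 2, alters the chain carried by that nitrogen's neighbouring carbon and so speaks only loosely to this change. Among the measured compounds shown here, with no direct precedent, a modest step is expected in this assay, more probably toward a higher number than a lower one, but not certainly beyond the scatter. Compound 3 is therefore estimated at 15 nM, with a range of 4 nM to 60 nM, which corresponds to an expected step of a 2.3-fold higher number from compound 2 to compound 3 (0.37 log units; beyond the scatter).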

Compound 3, inhibition constant: 1.2 nM
For compound 3 the middle estimate is 13-fold (1.10 log units) above the measured one, and the stated range ends above it.
By their numbers in this assay, from the lowest: compound 3; then compound 2; then compound 1.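

In this assay, methyl in place of hydrogen on the amine nitrogen gives a 5.3-fold lower number from compound 2 to compound 3 (0.73 log units; beyond the scatter). This shows that the nitrogen, whose other neighbour is a saturated chain carbon, can carry a methyl without any loss on this read-out, and that the number moves down by a modest step beyond the scatter. With the chain exchange included, 3-methyl-1-(methylamino)butyl in place of 1-amino-3-phenylpropyl gives an 800-fold lower number from compound 1 to compound 3 (2.91 log units; beyond the scatter), so the amine nitrogen joins the chain as a second place where a single change lowers the number, although no measurement given here accounts for the step.

The compounds shown leave open whether an ethyl group or a longer chain on this nitrogen, a second methyl on it, or an acetyl group in place of the methyl would lower the number further or raise it again. Within the data shown here, they also leave open whether methyl on the amine nitrogen of compound 1 would give a step of similar size, as the only pair with this change carries the 1-amino-3-methylbutyl chain.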